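The source may report more compounds than this note shows. Statements on the series, on what has been measured and on what is new or still open speak of the compounds shown alone.

Measured in a functional assay on HCT-116 cells (Homo sapiens) for cytotoxicity, read by MTT assay, with a stated time of 72 h; a higher number here means a weaker inhibitor, a lower number a stronger inhibitor:
compound 1 `O=C(NCc1ccc(F)cc1)c1nc(Br)c2cccnc2c1NCCCNc1c(C(=O)NCc2ccc(F)cc2)nc(Br)c2cccnc12` — reported only as a limit, > 20000 nM.
compound 2 `Nc1ccc(Nc2c(C(=O)NCc3ccc(F)cc3)nc(Br)c3cccnc23)cc1` — 7000 nM.
compound 3 `CS(=O)(=O)NCCCN(c1nc(C(=O)NCc2ccc(F)cc2)c(O)c2ncccc12)S(C)(=O)=O` — 7000 nM.

Compound 1 sits at the limit of > 20000 nM in this assay, at which 1 of the 3 values shown sits, so its figure is not a number and cannot be ranked against the other two. Compound 2 and compound 3 read the same in this assay at the digits given, and their gap lies within the scatter, so no order between them is claimed.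

The unmeasured candidate is compound 4 `C[C@H](Nc1c(C(=O)NCc2ccc(F)cc2)nc(Br)c2cccnc12)c1ccccc1`. It differs from compound 2 by 1-phenylethyl in place of 4-aminophenyl on a nitrogen on an aromatic ring. For the measured compounds named here, no measured pair in the set isolates this kind of change, so the size of the step must be judged without precedent: the expectation is a step in this assay of no more than the scatter in either direction, with slight room for a loss or a gain that cannot be resolved here.

For compound 4 the estimated half-maximal inhibitory concentration in this assay is 7000 nM, with an expected range from 2500 nM to 20000 nM. This estimate implies a step of no change at the digits printed from compound 2 to compound 4 (within the scatter), expected to remain within the usual scatter.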

Compound 4, half-maximal inhibitory concentration: > 20000 nM
Compound 4: a limit, no number (the forecaster's own chance of this, stated with the estimate: 15%); middle value at least 2.8-fold (0.45 log units) from the limit.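

In this assay, this position now has a readable step: 1-phenylethyl in place of 4-aminophenyl on a nitrogen on an aromatic ring gives an at least 2.8-fold higher number from compound 2 to compound 4 (0.45 log units; beyond the scatter). Compound 4 reads > 20000 nM, which is a limit and not a number. The swap is therefore a loss rather than a neutral exchange at this position, but its size is known only as a lower bound, and the reading is one of two at the same limit: the limit of > 20000 nM in this assay, at which 2 of the 4 values shown sit.

The change removes the amine of 4-aminophenyl and adds a methyl branch and a defined stereocentre all at once, so the compounds shown do not tell these apart. An unsubstituted phenyl, a benzyl or the opposite enantiomer of 1-phenylethyl on the same nitrogen would separate them.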